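This account rests on a few compounds, and the source may have more. Where it says the series, first, only, none or still open, it means among the compounds named here.

Within the data shown here, in a functional assay on DU-145 cells (Homo sapiens) for cytotoxicity, read by MTT assay (a lower number here means a stronger inhibitor, a higher number a weaker inhibitor), compound 3 (`CC(=O)OCCC(=O)O[C@H](CC=C(C)C)C1=CC(=O)c2c(O)ccc(O)c2C1=O`) gives 15700 nM and compound 1 (`CC(C)=CC[C@@H](OC[C@H](C)O)C1=CC(=O)c2c(O)ccc(O)c2C1=O`) gives 24500 nM within the scatter of each other (a 1.6-fold lower number from compound 1 to compound 3 (0.19 log units; within the scatter)), and these are the only two true numbers so far. Compound 2 (`CC(C)=CC[C@@H](OC(=O)c1ccco1)C1=CC(=O)c2c(O)ccc(O)c2C1=O`) reads > 100000 nM as a limit of the assay. Compound 4 (`CC[C@](C)(O)CC(=O)O[C@H](CC=C(C)C)C1=CC(=O)c2c(O)ccc(O)c2C1=O`) departs from compound 3 in one place (1-hydroxy-1-methylpropyl in place of acetoxymethyl on a saturated chain carbon bound to a carbonyl carbon), with 1-hydroxy-1-methylpropyl in place of acetoxymethyl on a saturated chain carbon bound to a carbonyl carbon. Among the measured compounds shown here, the one large measured change, furan-2-yl giving way to 2-acetoxyethyl on a carbonyl carbon (an at least 6.3-fold lower number from compound 2 to compound 3 (0.80 log units; beyond the scatter)), lies beyond the scatter, but compound 4 enters with no ring. No step beyond the scatter is therefore expected in this assay here, and the expected change is a 1.0-fold higher number from compound 3 to compound 4 (0.01 log units; within the scatter) only. Compound 4 is estimated at 16000 nM with an expected range from 6000 nM to 45000 nM in this assay.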

Compound 4, half-maximal inhibitory concentration: 20500 nM
For compound 4 the middle estimate is 1.3-fold (0.11 log units) below the measured one; the measured number falls inside the stated range.
By their numbers in this assay, from the lowest: compounds 3, 4 and 1 (each within the scatter of the next). At a limit, above all of these: compound 2.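

In this assay, 1-hydroxy-1-methylpropyl in place of acetoxymethyl, on a saturated chain carbon bound to a carbonyl carbon, brings in a hydrogen-bond donor and a defined stereocentre, yet the step stays within the scatter (a 1.3-fold higher number from compound 3 to compound 4 (0.12 log units; within the scatter)), as does the step from the ether (a 1.2-fold lower number from compound 1 to compound 4 (0.08 log units; within the scatter)). A second acyl group with no ring now also stands apart from furan-2-yl (an at least 4.8-fold lower number from compound 2 to compound 4 (0.68 log units; beyond the scatter)). The value of compound 2 is a limit: the limit of > 100000 nM in this assay, at which 1 of the 4 values shown sits.

Going by these compounds, whether an amine, a carboxylic acid or a longer chain at this place would give a step beyond the scatter stays open. So does whether a phenyl ring would read like furan-2-yl.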